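This account rests on a few compounds, and the source may have more. Where it says the series, first, only, none or still open, it means among the compounds named here.

Compound 1 `CN1CCC(NC(=O)c2ccc(Cn3nc(-c4cnn(C)c4)c4ccccc4c3=O)cc2)CC1`: 54300 nM
Compound 2 `Cc1noc(C)c1-c1nn(Cc2ccc(C(=O)N3CCCCC3)cc2)c(=O)c2ccccc12`: 86200 nM

In a functional assay on A549 cells (Homo sapiens) for antiproliferative activity, read by MTT assay, with a stated time of 72 h (a higher number here means a weaker inhibitor, a lower number a stronger inhibitor), compound 1 has the lower of the two numbers, yet compound 2 sits within the scatter of it, so no order between the two can be read. Compound 3 `Cn1cc(-c2nn(Cc3ccc(C(=O)NC4CC4)cc3)c(=O)c3ccccc23)cn1` differs from compound 1 by cyclopropyl in place of 1-methylpiperidin-4-yl on an amide-type nitrogen. Going by the values given here, no step between measured compounds shows what this change does. Since compound 1 gives 54300 nM in this assay, compound 3 is expected to land in the same weak range, with the step of a 1.1-fold higher number from compound 1 to compound 3 (0.04 log units; within the scatter) expected to stay within the scatter. Compound 3 is estimated at 60000 nM, between 20000 nM and 180000 nM.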

Compound 3, half-maximal inhibitory concentration: 51200 nM
Compound 3: middle estimate off by 1.2-fold (0.07 log units), on the high side; the measured number falls inside the stated range.
By their numbers in this assay, from the lowest: compounds 3, 1 and 2 (each within the scatter of the next).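

In this assay the exchange of 1-methylpiperidin-4-yl for cyclopropyl on the amide-type nitrogen gives a 1.1-fold lower number from compound 1 to compound 3 (0.03 log units; within the scatter) and so stays within the scatter. At this position, then, the smaller carbon-only ring and the larger ring holding a nitrogen read alike, and both compounds remain in the same weak range. No measured evidence accompanies this result to account for it. The compounds shown leave open whether an amine or a carboxylic acid on this nitrogen would move the number beyond the scatter.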